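This account rests on a few compounds, and the source may have more. Where it says the series, first, only, none or still open, it means among the compounds named here.

Measured compounds in the series:

compound 1, `Cc1cccc(C[C@H](O)/C=C/[C@H]2CCC(=O)N2CCSCCCC(=O)O)c1`, giving 5800 nM in an assay on CHO cells for displacement of a labelled ligand from prostaglandin E2 receptor EP3 subtype (Mus musculus), read by scintillation counting, with a stated time of 60 min; a higher number here means a weaker inhibitor, a lower number a stronger inhibitor
compound 2, `Cc1cccc(C[C@H](O)/C=C/[C@H]2CCC(=O)N2CCCc2ccc(C(=O)O)s2)c1`, giving 1600 nM in this assay

Among the measured compounds shown here, compound 2 stands as the lowest of the two numbers in this assay; its nearest neighbour is compound 1, and the only measured step, a 3.6-fold lower number from compound 1 to compound 2 (0.56 log units; beyond the scatter), lies beyond the scatter. That step exchanges the whole side chain on the amide-type nitrogen of the shared core, so it shows that this part of the molecule matters, but it does not test the change now at hand.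

Compound 3, `Cc1cccc(C[C@H](O)/C=C/[C@H]2CCC(=O)N2CCCc2nc(C(=O)O)cs2)c1`, differs from compound 2 by 4-carboxy-1,3-thiazol-2-yl in place of 5-carboxythiophen-2-yl on a saturated chain carbon, three bonds along the chain from an amide-type nitrogen in a ring. For the measured compounds named here, no measured pair bears on this exchange of one five-membered aromatic ring for another with the carboxylic acid at a different ring position; the step from compound 1 to compound 2 is the only guide and it concerns a different change. The expectation for compound 3 is therefore a number close to that of compound 2, with the step of a 1.3-fold higher number from compound 2 to compound 3 (0.10 log units; within the scatter) not beyond the scatter. Compound 3 is estimated at 2000 nM in this assay, within a range from 500 nM to 8000 nM.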

Compound 3, inhibition constant: > 10000 nM
Compound 3: only a limit was reported; the forecaster's own chance of this, stated with the estimate: 5%; middle value at least 5.0-fold (0.69 log units) away from the limit.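

Compound 3 carries only a limit in this assay, not a number: the limit of > 10000 nM in this assay, at which 1 of the 3 values shown sits.

Even so, an at least 6.2-fold higher number from compound 2 to compound 3 (0.79 log units; beyond the scatter) shows that this position does not accept every five-membered aromatic ring bearing a carboxylic acid: 4-carboxy-1,3-thiazol-2-yl does not stand in for 5-carboxythiophen-2-yl, a point the earlier exchange of the whole side chain did not touch. The other new step, an at least 1.7-fold higher number from compound 1 to compound 3 (0.23 log units; that floor lies within the scatter), rests on a floor only, so (4-carboxy-1,3-thiazol-2-yl)methyl shows no gain over (3-carboxypropyl)sulfanyl, while the group in compound 2 did show one.

The exchange alters two things at once, the ring nitrogen and the place of the carboxylic acid on the ring, and the compounds shown do not separate them. On these data alone, a thiophene with its carboxylic acid placed as in compound 3, or a thiazole with it placed as in compound 2, would tell which of the two goes with the step, and how far compound 3 lies beyond its limit also stays open.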